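Swapping a Chlorinated Aromatic Ring for a Cyclobutyl Group

This account rests on a few compounds, and the source may have more. Where it says the series, first, only, none or still open, it means among the compounds named here.

Of the compounds shown here, three sharing one core have been measured in a physicochemical assay for solubility, read by HPLC; on this read-out higher numbers stand for higher solubility and lower numbers for lower solubility. Compound 1 `O=C(CC1CCCCC1)N1CCN(c2nc(=O)c3cc(C(F)(F)F)cc([N+](=O)[O-])c3s2)CC1` gives 0.12 ug/mL. Compound 2 `CC1COC2(CCN(c3nc(=O)c4cc(C(F)(F)F)cc([N+](=O)[O-])c4s3)CC2)O1` gives 0.94 ug/mL. Compound 3 `O=C(c1ccccc1Cl)N1CCN(c2nc(=O)c3cc(C(F)(F)F)cc([N+](=O)[O-])c3s2)CC1` gives 8.18 ug/mL, the highest of the three numbers, standing above compound 2 and further above compound 1. Within the data shown here, only one measured step changes a single group on a carbonyl carbon: a 68-fold higher number from compound 1 to compound 3 (1.83 log units; beyond the scatter), where 2-chlorophenyl took the place of cyclohexylmethyl. Compound 4 `O=C(C1CCC1)N1CCN(c2nc(=O)c3cc(C(F)(F)F)cc([N+](=O)[O-])c3s2)CC1` differs from compound 3 in one place: cyclobutyl in place of 2-chlorophenyl on a carbonyl carbon. This change undoes part of that step, returning from a six-membered aromatic ring with chlorine to a non-aromatic ring of carbon only, here a four-membered one without a chain. Among the measured compounds shown here, compound 1 and compound 3 are the only measured pair that bear on it, and their step was large. Compound 4 is therefore expected to give a lower number, with an estimated step of an 8.2-fold lower number from compound 3 to compound 4 (0.91 log units; beyond the scatter), to about 1 ug/mL, most likely between 0.2 ug/mL and 5 ug/mL.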

Compound 4, solubility: 39.3 ug/mL
Beside the measured number, compound 4's estimate is 39-fold (1.59 log units) below it; the whole stated range lies below it.
By their numbers in this assay, from the lowest: compound 1; then compound 2; then compound 3; then compound 4.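

In this assay the change gives a 4.8-fold higher number from compound 3 to compound 4 (0.68 log units; beyond the scatter) and so shows that an aromatic ring with chlorine is not required on this carbonyl carbon for the highest of the four numbers. The comparison with the other carbon-only ring gives a 330-fold higher number from compound 1 to compound 4 (2.52 log units; beyond the scatter) and so shows that the low number of compound 1 does not hold for every non-aromatic ring at this position. Which non-aromatic group sits on the carbonyl carbon therefore matters greatly here, and nothing available explains why these numbers move as they do. The compounds shown leave open whether ring size or the chain in cyclohexylmethyl accounts for the difference between compound 1 and compound 4. They also leave open how a cyclopropyl or cyclohexyl ring placed directly on the carbonyl carbon would read, or a cyclobutyl ring carrying an amine or a carboxylic acid.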